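The compounds below may be only part of what the source reports. "The series", "measured", "known", "first", "only" and "open" are said of these compounds alone.

The measured compounds and their numbers:

Compound 1, `CN(C(=O)NC(=O)c1ccc(Cl)cc1Cl)c1nc(C(F)(F)F)c(C(=O)N/N=C/c2cccc(C(F)(F)F)c2)s1`, gives 10.6 ug/mL in a functional assay on A549 cells (Homo sapiens) for inhibition, read by MTT assay, with a stated time of 72 h; on this read-out lower numbers stand for stronger inhibition and higher numbers for weaker inhibition.
Compound 2, `CN(C(=O)NC(=O)c1ccc(Cl)cc1Cl)c1nc(C(F)(F)F)c(C(=O)N/N=C/c2ccc(C(F)(F)F)cc2)s1`, gives 9.4 ug/mL in this assay.
Compound 3, `CN(C(=O)NC(=O)c1cccc(C(F)(F)F)c1)c1nc(C(F)(F)F)c(C(=O)N/N=C/c2ccc(C(F)(F)F)cc2)s1`, gives 6.2 ug/mL in this assay.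

The three numbers lie close together. From compound 1 to compound 2 the change is 4-(trifluoromethyl)phenyl in place of 3-(trifluoromethyl)phenyl on a carbon with a double bond to nitrogen, and the step it made was a 1.1-fold lower number from compound 1 to compound 2 (0.05 log units; within the scatter). From compound 2 to compound 3 a different group is exchanged, and the step was a 1.5-fold lower number from compound 2 to compound 3 (0.18 log units; within the scatter). The difference between the core of compound 1 and the core of compound 3 is not broken down here.

Compound 4, `CN(C(=O)NC(=O)c1ccc(C(F)(F)F)cc1)c1nc(C(F)(F)F)c(C(=O)N/N=C/c2ccc(C(F)(F)F)cc2)s1`, has not yet been measured in this assay. It differs from compound 3 by 4-(trifluoromethyl)phenyl in place of 3-(trifluoromethyl)phenyl on a carbonyl carbon. Among the measured compounds shown here, this is the same kind of change as the one from compound 1 to compound 2, but at a different place: there the group sits on a carbon with a double bond to nitrogen, whose other neighbour is a double-bonded nitrogen, while here it sits on a carbonyl carbon whose other neighbour is an amide-type nitrogen. The step from compound 3 to compound 4 in this assay is expected to be a 1.1-fold lower number from compound 3 to compound 4 (0.03 log units; within the scatter), because the same kind of change at the other place gave only a 1.1-fold lower number from compound 1 to compound 2 (0.05 log units; within the scatter). This rests on a single earlier example, so the expectation is uncertain. Compound 4 is therefore estimated at 5.8 ug/mL, with a likely range from 3 ug/mL to 11.5 ug/mL.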

Compound 4, half-maximal inhibitory concentration: > 100 ug/mL
Compound 4 gave a limit, no number (the forecaster's own chance of this, stated with the estimate: 3%); at least 17-fold (1.23 log units) between middle value and limit.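

The same exchange does not carry over from one core to the other in this assay: the same change on two cores in this assay, a 1.1-fold lower number (0.05 log units; within the scatter) from compound 1 to compound 2 and an at least 16-fold higher number (1.20 log units; beyond the scatter) from compound 3 to compound 4, at least 18-fold (1.25 log units) apart, beyond the scatter of two such steps

On the carbonyl carbon, 4-(trifluoromethyl)phenyl in place of 3-(trifluoromethyl)phenyl gives an at least 16-fold higher number from compound 3 to compound 4 (1.20 log units; beyond the scatter), and 4-(trifluoromethyl)phenyl in place of 2,4-dichlorophenyl gives an at least 10-fold higher number from compound 2 to compound 4 (1.02 log units; beyond the scatter), which sets compound 4 clearly apart from both of its neighbours. The reading for compound 4 is a limit and not a number, which leaves the full size of both steps unknown, and with only one pair for each place the result shows that the change can behave very differently in this series, but neither why this happens nor whether it would happen on other cores: the limit of > 100 ug/mL in this assay, at which 1 of the 4 values shown sits.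

Going by these compounds, it remains open whether a different group on the phenyl ring attached to the carbonyl carbon, such as a methoxy group or a nitrile, would give a number like that of compound 3 or a limit like that of compound 4. On these data alone, it is also open whether the large step on the carbonyl carbon would appear again with 3-(trifluoromethyl)phenyl on the carbon with a double bond to nitrogen.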